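Replacing the Amide with a Sulfonamide on the Ring Nitrogen

The source may report more compounds than this note shows. Statements on the series, on what has been measured and on what is new or still open speak of the compounds shown alone.

Compound 1 `O=C(c1ccc(Cl)cc1)N1CCC(NS(=O)(=O)c2cc(S(=O)(=O)c3ccccc3)ccc2C(F)(F)F)CC1`: 3100 nM
Compound 2 `O=C(c1ccc(C(F)(F)F)cc1)N1CCC(NS(=O)(=O)c2cc(S(=O)(=O)c3ccccc3)ccc2C(F)(F)F)CC1`: 6300 nM
Compound 3 `O=C(c1ccc(Cl)nc1)N1CCC(NS(=O)(=O)c2cc(S(=O)(=O)c3ccccc3)ccc2C(F)(F)F)CC1`: 25000 nM

The three measured compounds share one core and differ only in the group carried by the amine nitrogen in the ring. In a physicochemical assay for solubility (a lower number here means a less soluble compound, a higher number a more soluble compound), compound 1 gives 3100 nM, the lowest of the three numbers. Its neighbours lie above it: a 2.0-fold higher number from compound 1 to compound 2 (0.31 log units; beyond the scatter) and an 8.1-fold higher number from compound 1 to compound 3 (0.91 log units; beyond the scatter); between the other two, a 4.0-fold higher number from compound 2 to compound 3 (0.60 log units; beyond the scatter).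

Compound 4 `O=S(=O)(NC1CCN(S(=O)(=O)c2ccccc2)CC1)c1cc(S(=O)(=O)c2ccccc2)ccc1C(F)(F)F` has not yet been measured. It differs from compound 1 in one place: phenylsulfonyl in place of (4-chlorophenyl)carbonyl on an amine nitrogen in a ring.

Within the data shown here, no measured step makes this exact exchange, so the expectation rests on the two steps that alter the same position in compound 1, both of which were modest rises beyond the scatter. On that basis a modest rise is expected, a 1.6-fold higher number from compound 1 to compound 4 (0.21 log units; within the scatter), though the direction is uncertain given that the entering group has no match among the measured compounds. Compound 4 is therefore estimated at 5000 nM, with a range from 1500 nM to 16000 nM.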

Compound 4, solubility: 25000 nM
Compound 4: middle estimate off by 5.0-fold (0.70 log units), on the low side, and the stated range ends below it.
By their numbers in this assay, from the lowest: compound 1; then compound 2; then compounds 3 and 4 (each within the scatter of the next).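

Phenylsulfonyl is the first group shown on this ring nitrogen that is not joined through a carbonyl, and in this assay the number for compound 4 stands clear of those of two amides (an 8.1-fold higher number from compound 1 to compound 4 (0.91 log units; beyond the scatter); a 4.0-fold higher number from compound 2 to compound 4 (0.60 log units; beyond the scatter)). Against the third amide the reading is different (no change at the digits printed from compound 3 to compound 4 (within the scatter)), so two unlike groups, (6-chloropyridin-3-yl)carbonyl and phenylsulfonyl, give the same number at this position. Nothing measured here explains why these numbers fall as they do.

Going by these compounds, it remains open whether this level holds for other sulfonyl groups, such as methylsulfonyl or (4-chlorophenyl)sulfonyl, the latter matching the aromatic ring of compound 1 exactly. How an amine or a carboxylic acid on the entering aromatic ring would read is also unknown.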